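This account rests on a few compounds, and the source may have more. Where it says the series, first, only, none or still open, it means among the compounds named here.

Compound 1, with the structure `Cn1c(-c2ccccc2)nnc1[S+](C)[O-]`, and compound 2, with the structure `Cn1c(-c2ccccc2)nnc1S(C)(=O)=O`, share one core and differ only in one group. Compound 1 gives 18.6 mg/kg in a functional assay on the whole organism for antagonist activity, with Mus musculus as the target; a lower number here means that less compound is needed, a higher number that more compound is needed for the effect. Compound 2 gives 12.8 mg/kg in this assay. The change between them, (a group of 4 heavy atoms (1 carbon, 2 oxygen, 1 sulfur; no ring) in place of a group of 3 heavy atoms (1 carbon, 1 oxygen, 1 sulfur; no ring), on an aromatic carbon), moves the read-out by a 1.5-fold lower number from compound 1 to compound 2 (0.16 log units; within the scatter).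

Compound 3, with the structure `Cn1c(-c2cccc3ccccc23)nnc1[S+](C)[O-]`, carries a different core; how its core differs from that of compound 1 is not broken down here. For compound 3 only a limit is known in this assay, namely > 200 mg/kg, which is the upper bound of the measurement and not a number; this is the limit noted as the limit of > 200 mg/kg in this assay, at which 1 of the 3 values shown sits.

Compound 4, with the structure `Cn1c(-c2cccc3ccccc23)nnc1S(C)(=O)=O`, is not yet measured. It differs from compound 3 by a group of 4 heavy atoms (1 carbon, 2 oxygen, 1 sulfur; no ring) in place of a group of 3 heavy atoms (1 carbon, 1 oxygen, 1 sulfur; no ring), on an aromatic carbon. This is the same kind of change as that from compound 1 to compound 2, though the surroundings are not identical, as the two descriptions of the change show.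

Since the same kind of change gave only a 1.5-fold lower number from compound 1 to compound 2 (0.16 log units; within the scatter), a step within the scatter, compound 4 is expected to sit close to compound 3, and the estimated step is a step that the limit leaves unreadable from compound 3 to compound 4. Compound 4 is therefore expected to give about 250 mg/kg in this assay, with a range from 100 mg/kg to 600 mg/kg, and it is likely that only a limit will again be reported.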

Compound 4, dose for half-maximal effect: > 200 mg/kg
Compound 4 gave a limit, no number (the forecaster's own chance of this, stated with the estimate: 65%); the middle value does not contradict the limit.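

Compound 3 and compound 4 each give only a limit and not a number in this assay, so no step can be read between them: the limit of > 200 mg/kg in this assay, at which 2 of the 4 values shown sit.

The compounds shown leave open how far methylsulfonyl, set in place of the group it replaces, moves the read-out on the core of compound 3, and whether that change behaves there as it does on the core of compound 1.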